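The source may report more compounds than this note shows. Statements on the series, on what has been measured and on what is new or still open speak of the compounds shown alone.

Compound 1 `O=C1C=C(N2CCC2)C(=O)c2c1nc1n2[C@H]2OC[C@@H](O)[C@H]2OC1`: in a functional assay on ECa-109 cells for inhibition, with ECa-109 cell line (Homo sapiens) as the target, read by sulforhodamine B assay (on this read-out lower numbers stand for stronger inhibition and higher numbers for weaker inhibition), compound 1 reaches only the limit of > 16000 nM.
Compound 2 `O=C1C=C(Nc2ccc(Br)cc2)C(=O)c2c1nc1n2[C@H]2OC[C@@H](O)[C@H]2OC1`: in this assay compound 2 gives 2850 nM.
Compound 3 `Cc1ccc(NC2=CC(=O)c3nc4n(c3C2=O)[C@H]2OC[C@@H](O)[C@H]2OC4)cc1`: not yet measured in this assay.

Among the values shown, compound 2 holds the only true number; the value of compound 1 is a limit of the assay. Going by the values given here, the single measured step is an at least 5.6-fold lower number from compound 1 to compound 2 (0.74 log units; beyond the scatter), in which (4-bromophenyl)amino replaces azetidin-1-yl; its size is known only as a lower bound because of the limit of > 16000 nM in this assay, at which 1 of the 2 values shown sits. The move from compound 2 to compound 3 is of a different kind: methyl in place of bromo on an aromatic carbon. The aryl amine stays in place, so the measured step speaks to the value of keeping an aromatic ring on the amine, not to swapping one small substituent for another on that ring. Among the compounds with values here, with no measured step of this kind, a change within the usual scatter is expected. Compound 3 is therefore estimated at 3500 nM, in the range 1200 nM to 12000 nM, meaning an expected step of a 1.2-fold higher number from compound 2 to compound 3 (0.09 log units; within the scatter).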

Compound 3, half-maximal inhibitory concentration: 3480 nM
Beside the measured number, compound 3's estimate is 1.0-fold (0.00 log units) above it; the measured number falls inside the stated range.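

In this assay, the para position of the aromatic ring tolerates this exchange: a 1.2-fold higher number from compound 2 to compound 3 (0.09 log units; within the scatter). Bromo and methyl, each a single heavy atom with no hydrogen-bond donor or acceptor, therefore cannot be told apart on this read-out, and the activity seen with compound 2 does not depend on bromine itself. As far as these compounds go, the comparison with the azetidine also now rests on two aryl amines rather than one, as the second shows an at least 4.5-fold lower number from compound 1 to compound 3 (0.66 log units; beyond the scatter), and this step too is beyond the scatter, so the gain is shared by both para-substituted phenylamino compounds, although its true size stays unknown because it is measured against a limit: the limit of > 16000 nM in this assay, at which 1 of the 3 values shown sits.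

The compounds shown leave open whether the same aromatic carbon would accept a group of a different kind, such as a methoxy group, a nitrile, a carboxylic acid or a dimethylamino group, as readily as it accepts bromo and methyl. They also leave open whether the aromatic ring itself matters, which an open-chain amine such as butylamino or a benzylamino group in the same place on the shared core could help to settle.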